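Swapping ethoxy for acetamido on a fused tetracyclic spiro scaffold

The source may hold more compounds than are shown below. What is called first, only, known or untested is meant among the compounds shown, and "the series" means these compounds.

Compound 2 `CCOc1ccc(-n2nncc2CN2C(=O)C3(C(C#N)=C(N)Oc4c3c3nc5ccccc5nc3c3ccccc43)c3ccccc32)cc1` is one of two compounds tested in a functional assay on A549 cells (Homo sapiens) for antiproliferative activity, read by MTT assay, with a stated time of 48 h (a higher number here means a weaker inhibitor, a lower number a stronger inhibitor), where compound 2 gives 25200 nM. For the measured compounds named here, its only measured neighbour, compound 1 `N#CC1=C(N)Oc2c(c3nc4ccccc4nc3c3ccccc23)C12C(=O)N(Cc1cnnn1-c1ccc(Br)cc1)c1ccccc12`, differs by ethoxy in place of bromo on an aromatic carbon and gives 44300 nM in this assay; the move a 1.8-fold lower number from compound 1 to compound 2 (0.25 log units; within the scatter) shows that those two numbers lie within the scatter of each other. Compound 3 `CC(=O)Nc1ccc(-n2nncc2CN2C(=O)C3(C(C#N)=C(N)Oc4c3c3nc5ccccc5nc3c3ccccc43)c3ccccc32)cc1` takes the step (acetamido in place of ethoxy on an aromatic carbon). Going by the values given here, no measured pair shows this exchange, and the single known step concerns a different group at the same position, so it offers only the hint that changes at this aromatic carbon have so far moved the number little. Compound 3 is therefore expected to land near compound 2, with an expected step of a 1.2-fold higher number from compound 2 to compound 3 (0.08 log units; within the scatter) in this assay. The estimate for compound 3 is 30000 nM, with a range from 10000 nM to 90000 nM.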

Compound 3, half-maximal inhibitory concentration: > 50000 nM
Compound 3: no number, only a limit (the forecaster's own chance of this, stated with the estimate: 10%); middle value at least 1.6-fold (0.22 log units) away from the limit.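

In this assay compound 3 gives > 50000 nM, which is a limit of the assay and not a number. For the compounds shown here, that limit still allows two readings, an at least 1.9-fold higher number from compound 2 to compound 3 (0.29 log units; that floor lies within the scatter) and an at least 1.1-fold higher number from compound 1 to compound 3 (0.05 log units; that floor lies within the scatter), so acetamido, the first group here to bring a hydrogen-bond donor to this aromatic carbon, shows no sign of lowering the number, though these floors do not establish a real loss either. Across bromo, ethoxy and acetamido, no step yet stands beyond the scatter, so the three groups cannot be put in order.

On these data alone, how far the true value of compound 3 lies past its limit stays open. Also open, as far as these compounds go, is whether an amine, a carboxylic acid or a longer alkoxy chain on this carbon would give a number clearly apart from these three.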